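Chain lengthening on the thiadiazole of an oxime ether series

This account rests on a few compounds, and the source may have more. Where it says the series, first, only, none or still open, it means among the compounds named here.

Measured compounds:
compound 1, `Cc1nnsc1CO/N=C/c1c(C)nn(C)c1Cl`: > 50000 nM
compound 2, `CCc1nnsc1CO/N=C/c1c(C)nn(C)c1Cl`: > 50000 nM

In a functional assay on Huh-7 cells (Homo sapiens) for inhibition, read by MTT assay, with a stated time of 48 h (on this read-out higher numbers stand for weaker inhibition and lower numbers for stronger inhibition), compound 1 gives > 50000 nM, which is a limit of the assay and not a number. In this assay compound 2 gives > 50000 nM, likewise a limit and not a number. Both values therefore sit at the limit of > 50000 nM in this assay, at which 2 of the 2 values shown sit, and the step that the two limits leave unreadable from compound 1 to compound 2 cannot be read. Compound 2 thus stands at the limit, with no measured number to place it more closely.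

Compound 3, `CCCc1nnsc1CO/N=C/c1c(C)nn(C)c1Cl`, differs from compound 2 by methyl in place of hydrogen on a saturated chain carbon, two bonds along the chain from an aromatic carbon. Within the data shown here, the only measured step bearing on this change, a step that the two limits leave unreadable from compound 1 to compound 2, gives no readable size, so no direction beyond the scatter can be drawn from it. Compound 3 is expected to remain at or past the limit, with the step that the limit leaves unreadable from compound 2 to compound 3 estimated as not readable. The estimate for compound 3 is 80000 nM, within 20000 nM to 300000 nM.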

Compound 3, half-maximal inhibitory concentration: > 50000 nM
Compound 3: a limit, no number; the forecaster's own chance of this, stated with the estimate: 85%; the middle value lies beyond the limit too.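

No step among compound 1, compound 2 and compound 3 can be read, since all three values are limits and not numbers: the limit of > 50000 nM in this assay, at which 3 of the 3 values shown sit.

The compounds shown leave open whether any chain on the shared core gives a number rather than a limit in this assay.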